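Moving the Pyridine Nitrogen on a Shared Core

The source may hold more compounds than are shown below. What is called first, only, known or untested is meant among the compounds shown, and "the series" means these compounds.

Compound 3 `Oc1ccccc1-c1cc(-c2ccccn2)cc(-c2ccccc2O)n1` is one of three compounds that share a core and differ only in a small aromatic group on it. In a functional assay on DU-145 cells (Homo sapiens) for cytotoxicity, read by CCK-8 assay (a lower number here means a stronger inhibitor, a higher number a weaker inhibitor), compound 3 gives > 50000 nM, which is a limit of the assay rather than a number. Compound 1 `Oc1ccccc1-c1cc(-c2cccs2)cc(-c2ccccc2O)n1` gives > 50000 nM in this assay, also a limit. Compound 2 `Oc1ccccc1-c1cc(-c2ccco2)cc(-c2ccccc2O)n1` gives > 50000 nM in this assay, again a limit. Because all three sit at the limit of > 50000 nM in this assay, at which 3 of the 3 values shown sit, the steps a step that the two limits leave unreadable from compound 1 to compound 2, a step that the two limits leave unreadable from compound 1 to compound 3 and a step that the two limits leave unreadable from compound 2 to compound 3 cannot be sized. Compound 4 `Oc1ccccc1-c1cc(-c2cccnc2)cc(-c2ccccc2O)n1` differs from compound 3 by pyridin-3-yl in place of pyridin-2-yl on an aromatic carbon. Among the measured compounds shown here, no measured step shows how this change acts, so compound 4 is expected to stay at the limit, with an expected step that the limit leaves unreadable from compound 3 to compound 4. The estimate for compound 4 is 80000 nM, between 30000 nM and 300000 nM.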

Compound 4, half-maximal inhibitory concentration: > 50000 nM
Compound 4 gave a limit, no number (the forecaster's own chance of this, stated with the estimate: 85%); the middle value is on the limit's open side.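

Compound 4 also gives only a limit, and no step from compound 1, compound 2 or compound 3 to compound 4 can be read: the limit of > 50000 nM in this assay, at which 4 of the 4 values shown sit.

The compounds shown leave open whether changing this small aromatic group alters the result at all in this assay.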